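An Aryl Amine Replaces the Hexyl Chain

The compounds below may be only part of what the source reports. "The series", "measured", "known", "first", "only" and "open" are said of these compounds alone.

Compound 3 `CCCCCCNc1cccc(NC(=O)c2ccc(OCCC)cc2)n1` bears a hexylamino group on the shared core. In an in vitro assay on HEK-tsA201 cells for antagonist activity at Neuronal acetylcholine receptor; alpha4/beta2 (Homo sapiens), read by fluorescence and calcium flux (a lower number here means a stronger inhibitor, a higher number a weaker inhibitor), compound 3 gives only the limit > 100000 nM, not a number. Compound 2 `CCCCCNc1cccc(NC(=O)c2ccc(OCCC)cc2)n1`, the pentylamino analogue, likewise gives only the limit > 100000 nM. Compound 1 `CCCOc1ccc(C(=O)Nc2cccc(C)n2)cc1`, with methyl at that position, gives 7500 nM. The step of an at least 13-fold higher number from compound 1 to compound 3 (1.12 log units; beyond the scatter) was large, and the step that the two limits leave unreadable from compound 2 to compound 3 cannot be read because of the limit of > 100000 nM in this assay, at which 2 of the 3 values shown sit. The unmeasured compound 4 `CCCOc1ccc(C(=O)Nc2cccc(Nc3ccccc3F)n2)cc1` differs from compound 3 by 2-fluorophenyl in place of hexyl on a nitrogen on an aromatic ring. Going by the values given here, no measured step covers an aryl group on that nitrogen, so the expectation rests only on compound 3 sitting at a limit. Compound 4 is therefore expected to remain weak, with an estimated step of an at least 1.6-fold lower number from compound 3 to compound 4 (0.22 log units; that floor lies within the scatter). The estimated value for compound 4 is 60000 nM, expected between 15000 nM and 200000 nM.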

Compound 4, half-maximal inhibitory concentration: > 100000 nM
Compound 4: a limit, no number; the forecaster's own chance of this, stated with the estimate: 50%; at least 1.6-fold (0.22 log units) between middle value and limit.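

Putting 2-fluorophenyl in place of hexyl leaves compound 4 at a limit in this assay, not a number, so an aryl group on this nitrogen gives no more of a readable value than the alkyl chains did. The step of an at least 13-fold higher number from compound 1 to compound 4 (1.12 log units; beyond the scatter) was large, so (2-fluorophenyl)amino, like pentylamino and hexylamino, reads on the weaker side of the methyl in compound 1. The steps among compound 2, compound 3 and compound 4 cannot be read: the limit of > 100000 nM in this assay, at which 3 of the 4 values shown sit.

On these data alone, their order therefore stays open. So does whether a plain amino group, a methylamino group or an unsubstituted phenylamino group on this carbon would return a number.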